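Sulfonamide series: aryl methyl to chloro exchange

The compounds below may be only part of what the source reports. "The series", "measured", "known", "first", "only" and "open" are said of these compounds alone.

Of the compounds shown here, three on the shared core have been tested in a functional assay on CFPAC-1 cells (Homo sapiens) for inhibition, read by MTT assay, with a stated time of 72 h; a higher number here means a weaker inhibitor, a lower number a stronger inhibitor. Compound 1 `O=c1cc(Cn2cc(CCCCO)nn2)c2ccc(O)cc2o1` reports only a limit in this assay, > 100000 nM. Compound 1 therefore sits at the limit of > 100000 nM in this assay, at which 1 of the 3 values shown sits. Compound 2 `CCCCc1ccc(-c2cn(Cc3cc(=O)oc4cc(O)ccc34)nn2)cc1` gives 69800 nM in this assay. Compound 3 `Cc1ccc(S(=O)(=O)NCc2cn(Cc3cc(=O)oc4cc(O)ccc34)nn2)cc1` gives 68900 nM in this assay, and the gap to compound 2 lies within the usual scatter, so the two stand together and no order between them can be read from the numbers.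

Compound 4 `O=c1cc(Cn2cc(CNS(=O)(=O)c3ccc(Cl)cc3)nn2)c2ccc(O)cc2o1` differs from compound 3 by chloro in place of methyl on an aromatic carbon, in words chloro in place of methyl on an aromatic carbon, with the change cut one bond further out reading (4-methylphenyl)sulfonyl to (4-chlorophenyl)sulfonyl. Within the data shown here, no measured pair in the set separates a methyl from a chloro, so the size of this move rests on nothing measured here. Compound 2 with 69800 nM and compound 3 with 68900 nM sit together despite quite different side chains, which argues for a small effect of a single peripheral substituent. The expected step is a 1.1-fold lower number from compound 3 to compound 4 (0.06 log units; within the scatter), none beyond the scatter. Compound 4 is estimated at 60000 nM in this assay, with a range from 25000 nM to 150000 nM.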

Compound 4, half-maximal inhibitory concentration: 81900 nM
Compound 4: the middle estimate sits 1.4-fold (0.14 log units) below what was measured; measured number inside the range.
By their numbers in this assay, from the lowest: compounds 3, 2 and 4 (each within the scatter of the next). At a limit, above all of these: compound 1.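

Working notes on the sulfonamide series: in this assay, chloro in place of methyl on the aromatic carbon gives a 1.2-fold higher number from compound 3 to compound 4 (0.08 log units; within the scatter) and so provides the first measured pair at this position, on the six-membered aromatic ring and para to a large group. The step does not separate the two substituents, so this pair gives no order between methyl and chloro, and the exchange leaves the number of the series unmoved within the scatter. Nothing among the measurements shown accounts for the size of this step, and none of them bears on how either substituent acts at this position.

Still open, from the compounds shown here alone, is whether any other group at this position, such as a methoxy, a nitro, an amine or a carboxylic acid, would give a step beyond the scatter, since methyl and chloro are the only two substituents compared here. Also open is what the sulfonyl link itself contributes, as no compound shown replaces it with a plain amide or a longer chain while keeping the 4-chlorophenyl or 4-methylphenyl group in place.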